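This account rests on a few compounds, and the source may have more. Where it says the series, first, only, none or still open, it means among the compounds named here.

Of the compounds shown here, three have numbers so far in a functional assay on A549 cells (Homo sapiens) for inhibition, read by sulforhodamine B assay, with a stated time of 48 h (a higher number here means a weaker inhibitor of growth, a lower number a stronger inhibitor of growth), and they spread widely. Compound 1 (`COc1ccc(/C=C/C(=O)/C=C/c2cc(OC)c(OC)c(OC)c2)cc1OC`) stands at 1210 nM here, compound 2 (`COc1cc(/C=C/C(=O)/C=C/c2sccc2C)cc(OC)c1OC`) at 9310 nM here, and compound 3 (`COc1cc(C=C(C(=O)/C=C/c2ccc(OC)c(OC)c2)C(=O)/C=C/c2ccc(OC)c(OC)c2)ccc1O`) at 530 nM as the lowest number of the three, beyond the scatter from both others.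

Compound 4 (`COc1ccc(/C=C/C(=O)C(=Cc2cccc(F)c2)C(=O)/C=C/c2ccc(OC)c(OC)c2)cc1OC`) has no number yet and is read against compound 3. The change is 3-fluorophenyl in place of 4-hydroxy-3-methoxyphenyl on a double-bonded chain carbon bound to a double-bonded chain carbon. For the measured compounds named here, no two measured compounds differ in one place only, so nothing yet shows what such a swap does.

Going by the values given here, the only guide is the values themselves: compound 3 (530 nM) and compound 1 (1210 nM) lie closer together than either lies to compound 2 (9310 nM). Among the compounds with values here, with no measured step to lean on, a modest step toward a higher number is expected and estimated here (a 1.4-fold higher number from compound 3 to compound 4 (0.15 log units; within the scatter)), possibly none beyond the scatter. In this assay the estimate for compound 4 is 750 nM with an expected range from 260 nM to 2200 nM for repeat readings.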

Compound 4, concentration for 50% growth inhibition: 580 nM
The estimate for compound 4 lay 1.3-fold (0.11 log units) above the measured number; low and high end bracket the measured number.
By their numbers in this assay, from the lowest: compounds 3 and 4 (each within the scatter of the next); then compound 1; then compound 2.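

In this assay, for the compounds shown here, 3-fluorophenyl in place of 4-hydroxy-3-methoxyphenyl on a double-bonded chain carbon bound to a double-bonded chain carbon gives a 1.1-fold higher number from compound 3 to compound 4 (0.04 log units; within the scatter), the first step that isolates a single place. The entering group has no hydrogen-bond donor or acceptor and fewer heavy atoms than the group it replaces, yet the pair cannot be told apart in this assay, so this position accepts both aromatic groups without a step beyond the scatter. No measured property is available to explain why the two compounds read alike.

This rests on one pair, and it does not show whether the same holds for an unsubstituted phenyl, for a ring carrying an amine or a carboxylic acid, or for a longer chain at this place. It also leaves open whether the two outer 3,4-dimethoxyphenyl groups shared by compound 3 and compound 4 can be replaced with a similarly small step.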